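The source may report more compounds than this note shows. Statements on the series, on what has been measured and on what is new or still open speak of the compounds shown alone.

Measured so far in a functional assay on NCI-H460 cells (Homo sapiens) for antiproliferative activity, read by XTT assay, with a stated time of 72 h; on this read-out lower numbers stand for stronger inhibition and higher numbers for weaker inhibition: compound 1 `COc1ccc(-c2cc3ccccc3nc2/C=C/C(=O)c2ccc(O)cc2)cc1` gives 6930 nM; compound 2 `COc1ccc(-c2cc3ccccc3nc2/C=C/C(=O)c2c(OC)cccc2OC)cc1` gives 6630 nM.

Compound 2 stands at the lower of the two numbers, but the step of a 1.0-fold lower number from compound 1 to compound 2 (0.02 log units; within the scatter) is within the scatter, so the two compounds are not separated. Compound 3 `COc1ccc(-c2cc3ccccc3nc2/C=C/C(=O)c2ccc(N)cc2)cc1` is not yet measured and differs from compound 2 by 4-aminophenyl in place of 2,6-dimethoxyphenyl on a carbonyl carbon. The only step bearing on this position is a 1.0-fold lower number from compound 1 to compound 2 (0.02 log units; within the scatter), which was flat; exchanging the aryl group on the carbonyl carbon has shown no effect so far, and no step beyond the scatter is expected in this assay. Compound 3 is expected at 6500 nM, with a range from 3000 nM to 14000 nM. The expected step is a 1.0-fold lower number from compound 2 to compound 3 (0.01 log units; within the scatter), within the scatter.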

Compound 3, half-maximal inhibitory concentration: 7400 nM
Estimate against measurement, compound 3: 1.1-fold (0.06 log units) below; low and high end bracket the measured number.
By their numbers in this assay, from the lowest: compounds 2, 1 and 3 (each within the scatter of the next).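

In this assay, the aryl group on the carbonyl carbon has now taken three forms without any separation: a 1.1-fold higher number from compound 2 to compound 3 (0.05 log units; within the scatter) lies within the scatter, and so does a 1.1-fold higher number from compound 1 to compound 3 (0.03 log units; within the scatter). The second of these steps adds a narrower exchange to the series, amino in place of hydroxy on an aromatic carbon, and it is also flat. No measurement at hand accounts for this flatness. On these data alone, the effect of a carboxylic acid or a longer chain in place of the aryl group on the carbonyl carbon remains open. Changes to the shared core also remain open.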